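Replacing a nitrophenyl amide with a methoxyphenyl amide

This account rests on a few compounds, and the source may have more. Where it says the series, first, only, none or still open, it means among the compounds named here.

Three amides built on the shared core of compound 1 `CC(C)C(=O)Nc1c(C(O)(C(F)(F)F)C(F)(F)F)ccc2ccccc12` have been measured in an assay on LtK cells with ATP-sensitive inward rectifier potassium channel 11 (Homo sapiens) as the target; on this read-out lower numbers stand for an effect already at smaller amounts and higher numbers for an effect only at larger amounts of compound. Compound 1 gives 6630 nM, compound 2 `COCC(=O)Nc1c(C(O)(C(F)(F)F)C(F)(F)F)ccc2ccccc12` gives 213 nM, and compound 3 `O=C(Nc1c(C(O)(C(F)(F)F)C(F)(F)F)ccc2ccccc12)c1cccc([N+](=O)[O-])c1` gives 117 nM, which is the lowest of the three numbers. The steps of a 57-fold lower number from compound 1 to compound 3 (1.75 log units; beyond the scatter) and a 1.8-fold lower number from compound 2 to compound 3 (0.26 log units; within the scatter) show that the group on the carbonyl carbon matters, the change to an aromatic ring having by far the larger effect. Compound 4 `COc1ccc(C(=O)Nc2c(C(O)(C(F)(F)F)C(F)(F)F)ccc3ccccc23)cc1` carries 4-methoxyphenyl in place of 3-nitrophenyl on a carbonyl carbon. Since both aromatic amides share the large gain over compound 1, the expected step of a 1.3-fold higher number from compound 3 to compound 4 (0.11 log units; within the scatter) is small. Compound 4 is therefore estimated at 150 nM, within a range from 40 nM to 600 nM.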

Compound 4, half-maximal effective concentration: 417 nM
Beside the measured number, compound 4's estimate is 2.8-fold (0.44 log units) below it; the range from low to high includes it.
By their numbers in this assay, from the lowest: compounds 3, 2 and 4 (each within the scatter of the next, the first and the last beyond it); then compound 1.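

In this assay the two aromatic amides are not interchangeable: the step of a 3.6-fold higher number from compound 3 to compound 4 (0.55 log units; beyond the scatter) lies beyond the scatter, so on this carbonyl carbon the groups carried by the ring count, not just the ring itself. The step of a 16-fold lower number from compound 1 to compound 4 (1.20 log units; beyond the scatter) keeps a large gain over the isopropyl amide, while the step of a 2.0-fold higher number from compound 2 to compound 4 (0.29 log units; within the scatter) stays within the scatter. No measured evidence explains the difference between 3-nitrophenyl and 4-methoxyphenyl.

Those two groups differ both in what the ring carries and in where it carries it, and the compounds shown do not separate the two. The 4-nitrophenyl and 3-methoxyphenyl amides would be needed to tell them apart.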